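Vinyl sulfone and malonate series on breast cancer cell growth

The source may hold more compounds than are shown below. What is called first, only, known or untested is meant among the compounds shown, and "the series" means these compounds.

Measured so far:
compound 1, `CCOC(=O)C(=Cc1c(-c2ccccc2)[nH]c2ccccc12)C(=O)OCC`, in a functional assay on T47D cells (Homo sapiens) for inhibition, read by sulforhodamine B assay, with a stated time of 48 h (on this read-out higher numbers stand for weaker inhibition of growth and lower numbers for stronger inhibition of growth), gives 2700 nM
compound 2, `COc1ccc(-c2[nH]c3ccc(OC)cc3c2/C=C(\C#N)S(=O)(=O)c2ccccc2)cc1`, in this assay gives 905 nM
compound 3, `CC(=O)/C(=C\c1c(-c2ccccc2)[nH]c2ccccc12)S(=O)(=O)c1ccccc1`, in this assay gives 1400 nM

Compound 3 holds the second highest of the three numbers in this assay. Its nearest neighbour is compound 2, whose number is lower but within the scatter; the furthest is compound 1, whose number is higher, again within the scatter. For the measured compounds named here, on these three numbers no compound separates from the others beyond the scatter.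

Compound 4, `N#C/C(=C\c1c(-c2ccccc2)[nH]c2ccccc12)S(=O)(=O)c1ccccc1`, has not yet been measured. It differs from compound 3 in one place: cyano in place of acetyl on a double-bonded chain carbon bound to a double-bonded chain carbon and a sulfonyl sulfur. Going by the values given here, no step between two measured compounds isolates this change. Compound 2 carries the same cyano-bearing chain but also two methoxy groups, so its number cannot be read as the effect of this change alone. A small step, if any, is expected, and its direction is uncertain. Compound 4 is expected to give about 1000 nM in this assay, with a range of 400 nM to 2500 nM. The expected step of a 1.4-fold lower number from compound 3 to compound 4 (0.15 log units; within the scatter) is estimated to lie within the scatter.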

Compound 4, concentration for 50% growth inhibition: 3800 nM
Beside the measured number, compound 4's estimate is 3.8-fold (0.58 log units) below it; the measured number lies above the stated range.
By their numbers in this assay, from the lowest: compounds 2, 3, 1 and 4 (each within the scatter of the next, the first and the last beyond it).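

In this assay, for the compounds shown here, the double-bonded chain carbon bound to a double-bonded chain carbon and a sulfonyl sulfur proves sensitive to the group it carries: cyano in place of acetyl gives a 2.7-fold higher number from compound 3 to compound 4 (0.43 log units; beyond the scatter), the first single-place change and one that lies beyond the scatter. Between these two groups, on the core shared by compound 3 and compound 4, acetyl gives the stronger inhibition of growth, though the size of the step is modest. No measurement at hand bears on why this step arises.

As far as these compounds go, whether the step carries over to a core bearing the two methoxy groups of compound 2 remains open. Also open, from the compounds shown here alone, is how a carboxylic acid, a primary amide or a longer ketone chain such as propanoyl would behave at this place.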